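The source may report more compounds than this note shows. Statements on the series, on what has been measured and on what is new or still open speak of the compounds shown alone.

Measured compounds:
- compound 1, `COc1cc(-c2nn(-c3cccc(NC(=O)Nc4ccc(Cl)c(Cl)c4)c3)cc2-c2ccncc2)ccc1Cl`, 388 nM in a functional assay on RPMI-8226 cells (Homo sapiens) for inhibition, read by sulforhodamine B assay, with a stated time of 48 h; on this read-out higher numbers stand for weaker inhibition of growth and lower numbers for stronger inhibition of growth
- compound 2, `O=C(Nc1cccc(-n2cc(-c3ccncc3)c(-c3ccc(Cl)c(O)c3)n2)c1)Nc1ccc(Cl)c(Cl)c1`, 1030 nM in this assay
- compound 3, `O=C(Nc1cccc(-n2cc(-c3ccncc3)c(-c3ccc(Cl)c(O)c3)n2)c1)Nc1cc(C(F)(F)F)cc(C(F)(F)F)c1`, 477 nM in this assay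

Compound 1 holds the lowest of the three numbers in this assay; compound 3 sits close to it, within the scatter, while compound 2 lies beyond the scatter, as the step of a 2.7-fold higher number from compound 1 to compound 2 (0.42 log units; beyond the scatter) shows. Compound 4, `COc1cc(-c2nn(-c3cccc(NC(=O)Nc4ccc(Cl)c(C(F)(F)F)c4)c3)cc2-c2ccncc2)ccc1Cl`, has not yet been measured. It differs from compound 1 in one place: trifluoromethyl in place of chloro on an aromatic carbon.

Among the compounds with values here, no measured step changes this exact group. Within the data shown here, the only single-point step, from compound 1 to compound 2, concerns the oxygen on the other aromatic ring, so it says nothing directly about the urea aryl. Among the measured compounds shown here, compounds 2 and 3, which differ in the aryl carried by the urea, show numbers in this assay of which the one for compound 3 is lower, and the two differ by more than the scatter. On that slender ground compound 4 is expected to give a number near that of compound 1 or somewhat lower, a step of a 1.3-fold lower number from compound 1 to compound 4 (0.11 log units; within the scatter). Compound 4 is thus estimated at 300 nM, within 120 nM to 800 nM.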

Compound 4, concentration for 50% growth inhibition: 868 nM
The estimate for compound 4 lay 2.9-fold (0.46 log units) below the measured number; the measured number lies above the stated range.
By their numbers in this assay, from the lowest: compounds 1, 3, 4 and 2 (each within the scatter of the next, the first and the last beyond it).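

In this assay, trifluoromethyl in place of chloro on this aromatic carbon, ortho to a chloro group, gives a 2.2-fold higher number from compound 1 to compound 4 (0.35 log units; beyond the scatter). Within the data shown here, this is the first single-place change on the urea aryl with the rest of compound 1 held fixed, and it shows that the number responds to this carbon's substituent: going from 3,4-dichlorophenyl to 4-chloro-3-(trifluoromethyl)phenyl moves it beyond the scatter, towards weaker inhibition of growth. The data offer no measurement that accounts for this step.

From the compounds shown here alone, whether fluoro, methyl or a nitrile on this carbon would match chloro or follow trifluoromethyl remains open. So does whether the same exchange would move the number in the same direction on compound 2, which carries a hydroxy group where compound 1 has methoxy.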